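This account rests on a few compounds, and the source may have more. Where it says the series, first, only, none or still open, it means among the compounds named here.

Measured in a functional assay on HeLa cells (Homo sapiens) for inhibition, read by CCK-8 assay, with a stated time of 48 h; on this read-out lower numbers stand for stronger inhibition and higher numbers for weaker inhibition:
Compound 1, `Fc1ccc(C2=NN(C3=NC(c4ccccc4)CS3)C(c3cccc4ccccc34)C2)cc1`: 12400 nM
Compound 2, `Cc1ccc(C2=NN(C3=NC(c4ccccc4)CS3)C(c3cccc4ccccc34)C2)cc1`: 4290 nM

Among these two, compound 2 gives the lowest number, and its nearest neighbour is compound 1, separated by a 2.9-fold lower number from compound 1 to compound 2 (0.46 log units; beyond the scatter). Compound 3, `Clc1ccc(C2=NN(C3=NC(c4ccccc4)CS3)C(c3cccc4ccccc34)C2)cc1`, differs from compound 2 by chloro in place of methyl on an aromatic carbon; cut one bond further out, the change reads 4-methylphenyl to 4-chlorophenyl. Among the compounds with values here, the only measured step at this place is a 2.9-fold lower number from compound 1 to compound 2 (0.46 log units; beyond the scatter), which swaps fluoro for methyl; no step from methyl to chloro has been measured, so the size of the coming step is uncertain. Since both neighbouring substituents at this place give numbers within a modest span, the expected step for compound 3 is small, most likely within the scatter, and in this assay compound 3 is expected to give 5500 nM, with a range from 2200 nM to 14000 nM. The estimated step is a 1.3-fold higher number from compound 2 to compound 3 (0.11 log units; within the scatter).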

Compound 3, half-maximal inhibitory concentration: 9940 nM
The estimate for compound 3 lay 1.8-fold (0.26 log units) below the measured number, within the range that was stated.
By their numbers in this assay, from the lowest: compound 2; then compounds 3 and 1 (each within the scatter of the next).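

At this position, para to a large group, the swap of methyl for chloro in this assay costs about as much as the earlier swap in the other direction suggested, with a step (a 2.3-fold higher number from compound 2 to compound 3 (0.36 log units; beyond the scatter)) that lies beyond the scatter. The two halogen-bearing compounds cannot be told apart, as the step between them (a 1.2-fold lower number from compound 1 to compound 3 (0.10 log units; within the scatter)) lies within the scatter, so among these three para substituents methyl alone stands out, and compound 2 keeps the lowest number. No measurement at hand explains this difference between methyl and the two halogens.

Still open, on these data alone, is how an ethyl, a methoxy, an amine or a carboxylic acid would behave at this same position. These three compounds also cannot show whether methyl would keep its lead with other changes elsewhere on the shared core.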